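This account rests on a few compounds, and the source may have more. Where it says the series, first, only, none or still open, it means among the compounds named here.

In an ADME assay on RAW264.7 cells (Mus musculus) for cytotoxicity, read by MTT assay, with a stated time of 24 h, in the presence of a further agent that is not named here (a lower number here means a stronger inhibitor, a higher number a weaker inhibitor), the measured compounds read:
- Compound 1 `COc1ccc(C(O)C2OC(=O)c3c(OC)cc(OC)cc32)cc1`: > 40000 nM (a limit)
- Compound 2 `CCOc1ccc(C(O)C2OC(=O)c3c(OC)cc(OC)cc32)cc1`: > 40000 nM (a limit)
- Compound 3 `COc1cc(OC)c2c(c1)C(C(O)c1ccc(OCCOc3ccccc3)cc1)OC2=O`: > 40000 nM (a limit)

Compound 3 has no numerical value, only the limit > 40000 nM. It shares this position with the other two compounds, as the record shows: the limit of > 40000 nM in this assay, at which 3 of the 3 values shown sit.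

Compound 4 `C=CCCOc1ccc(C(O)C2OC(=O)c3c(OC)cc(OC)cc32)cc1` departs from compound 3 as follows: vinyl in place of phenoxy on a saturated chain carbon, two bonds along the chain from an oxygen on an aromatic ring. In short, compound 4 carries vinyl where compound 3 carries phenoxy. The same difference can be read as 2-phenoxyethoxy to (but-3-en-1-yl)oxy.

The closest measured change is a step that the two limits leave unreadable from compound 2 to compound 3, which alters the same place. Two further changes bear on the chain: a step that the two limits leave unreadable from compound 1 to compound 2 and a step that the two limits leave unreadable from compound 1 to compound 3. None of these has a readable size, so they offer no measured effect to carry over. Across these three compounds, the chain changes never moved the result off the limit, so no step beyond the scatter is expected in this assay, and no direction can be assigned. The expected step is a step that the limit leaves unreadable from compound 3 to compound 4. For compound 4 the estimated value is 45000 nM, with an expected range from 25000 nM to 80000 nM.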

Compound 4, half-maximal inhibitory concentration: > 40000 nM
Compound 4 was reported as a limit (the forecaster's own chance of this, stated with the estimate: 85%); the middle value is on the limit's open side.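

In this assay compound 4 gives > 40000 nM, which is a limit. No step from compound 1, compound 2 or compound 3 to compound 4 can be read, because all four compounds stand only as limits: the limit of > 40000 nM in this assay, at which 4 of the 4 values shown sit.

The compounds shown leave open whether any of these chain changes alters the half-maximal inhibitory concentration, and in which direction.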